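From 2-chloro-6-fluorophenyl to cyclohexyl in compound 4

A few compounds are considered here, and "the series" means these few. Any claim that something is new, unique, unknown or untested is made for them only; others in the source may bear on it.

Measured so far in an ADME assay on microsomes from liver (Mus musculus) for metabolic stability, with a stated time of 10 min; a lower number here means that less of the compound is left, a higher number that more of the compound is left:
Compound 1 `CC(=O)N1CCC(O)(C(=O)N2CC[C@](c3ccc(C(OCc4c(F)cccc4F)(C(F)(F)F)C(F)(F)F)cc3)(S(=O)(=O)c3ccc(F)cc3)C2)CC1` gives 69%
Compound 2 `CC(=O)N1CCN(C(=O)N2CC[C@](c3ccc(C(OCc4c(F)cccc4F)(C(F)(F)F)C(F)(F)F)cc3)(S(=O)(=O)c3ccc(F)cc3)C2)CC1` gives 59%
Compound 3 `O=C(O)[C@H]1CC[C@H](C(=O)N2CC[C@](c3ccc(C(OCc4c(F)cccc4Cl)(C(F)(F)F)C(F)(F)F)cc3)(S(=O)(=O)c3ccc(F)cc3)C2)CC1` gives 87%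

Of these three, compound 3 stands highest, and its distances to compound 1 and to compound 2 both lie beyond the scatter. Compound 4 `O=C(O)[C@H]1CC[C@H](C(=O)N2CC[C@](c3ccc(C(OCC4CCCCC4)(C(F)(F)F)C(F)(F)F)cc3)(S(=O)(=O)c3ccc(F)cc3)C2)CC1` has not yet been measured. It carries cyclohexyl in place of 2-chloro-6-fluorophenyl on a saturated chain carbon bound to an oxygen on a saturated carbon, and the rest of compound 3 is kept.

Among the compounds with values here, only one measured step is available, a number 10 percentage points lower from compound 1 to compound 2 (within the scatter) and it concerns a different change, on a carbonyl carbon. Within the data shown here, no measured step touches the group that compound 4 alters, so the data give no direct guide to this change. The estimate therefore rests on the overall level alone. Compound 3 at 87% tops a very small set, and so the estimate is drawn towards compound 1 at 69% in this assay as a cautious guess. The expected change is a number 15 percentage points lower from compound 3 to compound 4 (beyond the scatter) and this is a rough estimate, since a result within the scatter would be no surprise. For compound 4 the estimated value is 72% with an expected range from 48% to 90% in this measurement.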

Compound 4, percent of the compound remaining: 78%
For compound 4 the middle estimate is 6 percentage points below the measured one, within the range that was stated.
By their numbers in this assay, from the lowest: compounds 2, 1, 4 and 3 (each within the scatter of the next, the first and the last beyond it).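

Within the data shown here, at this position this assay records a number 9 percentage points lower from compound 3 to compound 4 (within the scatter) for the first measured change here, cyclohexyl in place of 2-chloro-6-fluorophenyl on a saturated chain carbon bound to an oxygen on a saturated carbon. The earlier compounds shown here varied only the group on the carbonyl carbon, so they said nothing about this site. The new step shows that, with the rest of compound 3 kept, a non-aromatic ring of carbon only can replace an aromatic ring bearing chlorine and fluorine without a shift beyond the scatter in this read-out. Nothing among the available data bears on why the step has this size.

The compounds shown leave open which part of the change matters, the loss of the halogens or the loss of the aromatic ring, and a plain phenyl or an open hexyl chain at this place would separate the two. On these data alone, it also stays open whether the same change would read alike with 1-acetyl-4-hydroxypiperidin-4-yl or 4-acetylpiperazin-1-yl on the carbonyl carbon, rather than the group carrying the carboxylic acid.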